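The compounds below may be only part of what the source reports. "The series", "measured", "known", "first", "only" and "open" are said of these compounds alone.

Measured so far in a functional assay on the whole organism (strain albino) for inhibition, with Rattus norvegicus as the target, read by paw edema, with a stated time of 2 h, at a dose of 0.28 mmol/kg by the oral route; on this read-out lower numbers stand for less inhibition and higher numbers for more inhibition at the one dose given (going by the name of the read-out):
compound 1 `C=CCn1c(SCC(=O)c2ccccc2)nnc1-c1ccc(OC)cc1` — 53%
compound 2 `C=CCn1c(SC/C(=N/O)c2ccccc2)nnc1-c1cc(OC)c(OC)c(OC)c1` — 68%
compound 3 `COc1ccc(-c2nnc(SCC(=O)c3ccccc3)n2-c2ccccc2)cc1` — 57%

Compound 2 stands highest of the three; compound 3 and compound 1 are both beyond the scatter below it. The difference between the core of compound 1 and the core of compound 2 is not broken down here.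

Compound 1 and compound 3 differ in one place: phenyl in place of allyl on an aromatic nitrogen. That change gives a number 4 percentage points higher from compound 1 to compound 3 (within the scatter), a step within the scatter.

Compound 4 `COc1cc(-c2nnc(SC/C(=N/O)c3ccccc3)n2-c2ccccc2)cc(OC)c1OC` is not yet measured. It differs from compound 2 by phenyl in place of allyl on an aromatic nitrogen. This is the same kind of change as from compound 1 to compound 3, though the surroundings differ: in compound 1 the ring nitrogen sits next to the ring atom that bears a 4-methoxyphenyl group, in compound 2 next to two ring atoms that each bear a large group.

The step from compound 2 to compound 4 in this assay is expected to be a number 3 percentage points higher from compound 2 to compound 4 (within the scatter), about as small as the earlier one, because a number 4 percentage points higher from compound 1 to compound 3 (within the scatter) stayed within the scatter. Compound 4 is therefore estimated at 71%, between 60% and 82%, resting on one precedent only.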

Compound 4, a percentage reported as inhibition, in the whole organism at one dose (the size of the read-out at that dose, not a potency): 61%
Compound 4: middle estimate off by 10 percentage points, on the high side, and the stated range covers the measured number.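

In this assay, phenyl in place of allyl on an aromatic nitrogen gives a number 7 percentage points lower from compound 2 to compound 4 (within the scatter), so on this second core as well the step stays inside the usual scatter. Set beside the earlier step, the change carries over from one core to the other without a difference that can be read: the same change on two cores in this assay, a number 4 percentage points higher (within the scatter) from compound 1 to compound 3 and a number 7 percentage points lower (within the scatter) from compound 2 to compound 4, 11 percentage points apart, within the scatter of two such steps. This does not show that the change is without effect or that it acts identically on both cores, since two small steps of opposite sign fix neither its direction nor its true size, and two cores say little about any others in the series.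

As far as these compounds go, what a benzyl group or a longer chain such as butyl would give on that ring nitrogen stays open, as does the effect of an amine or a carboxylic acid on the entering phenyl. Also open, from the compounds shown here alone, is whether the step would stay this small at other doses or times, as each compound here has a single reading at one dose.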